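A few compounds are considered here, and "the series" means these few. Any claim that something is new, unique, unknown or untested is made for them only; others in the source may bear on it.

Measured so far in an ADME assay on BaF3 cells (Mus musculus) for cytotoxicity; a lower number here means that less compound is needed, a higher number that more compound is needed for the effect:
Compound 1 `NC(=O)c1ccc(Cn2ncc3c(Nc4ccc(OC(F)(F)F)cc4)ncnc32)cc1` gives > 10000 nM, which is a limit of the assay and not a number.
Compound 2 `NS(=O)(=O)c1cccc(-c2cc(Nc3ccc(OC(F)(F)F)cc3)ncn2)c1` gives > 10000 nM, likewise a limit of the assay.
Compound 3 `CN1CCN(C(=O)c2cc3c(Nc4ccc(OC(F)(F)F)cc4)ncnc3s2)CC1` gives 2690 nM.

Compound 1 thus stands at the limit of > 10000 nM in this assay, at which 2 of the 3 values shown sit, so on the numbers shown its position can be given only as this limit. Compound 4 `FC(F)(F)Oc1ccc(Nc2ncnc3c2cnn3CC2CCOC2)cc1` differs from compound 1 in one place: oxolan-3-yl in place of 4-carbamoylphenyl on a saturated chain carbon bound to an aromatic nitrogen. Within the data shown here, no step between measured compounds covers this change, so the step in this assay from compound 1 to compound 4 is expected to be small, none beyond the usual scatter, and compound 4 is expected to stay near the limit of this assay. The estimated value for compound 4 is 10000 nM, in the range from 4000 nM to 25000 nM. This estimate means a number no higher from compound 1 to compound 4 (the limit leaves the size open).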

Compound 4, half-maximal effective concentration: > 10000 nM
Compound 4 ended at the assay's limit; the forecaster's own chance of this, stated with the estimate: 65%; the middle value lies on the limit itself.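

No step from compound 1 to compound 4 can be read, since both sit at a limit of this assay and not at a number: the limit of > 10000 nM in this assay, at which 3 of the 4 values shown sit.

The compounds shown leave open whether oxolan-3-yl in place of 4-carbamoylphenyl changes the value at all.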